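A few compounds are considered here, and "the series" means these few. Any claim that something is new, unique, unknown or untested is made for them only; others in the source may bear on it.

Measured compounds:
compound 1 `COc1cc(C)cc(-c2c(-c3ccnc(-c4ccc(C(C)=O)cc4)c3)cnn2CC#N)c1` — 81%
compound 2 `Cc1cc(O)cc(-c2nn(CC#N)cc2-c2ccnc(-c3ccc(Oc4ccccc4)cc3)c2)c1` — 72%
compound 3 `COc1cc(C)cc(-c2nn(CC#N)cc2-c2ccnc(-c3ccc(N(C)C)cc3)c2)c1` — 87%

In a functional assay on NCI-H522 cells (Homo sapiens) for cytotoxicity, read by sulforhodamine B assay, with a stated time of 48 h, tested at 0.01 uM (on this read-out higher numbers stand for a weaker effect at the one concentration tested and lower numbers for a stronger effect), compound 3 gives 87%, the highest of the three numbers. Compound 1 gives 81%, which lies within the scatter of that, so the two cannot be ordered. Compound 2 gives 72%, a number beyond the scatter below compound 3. Compound 4 `Cc1cc(O)cc(-c2nn(CC#N)cc2-c2ccnc(-c3ccc(N(C)C)cc3)c2)c1` has not yet been measured. It differs from compound 3 in one place: hydrogen in place of methyl on an oxygen on an aromatic ring. Among the measured compounds shown here, no measured pair differs in that one place alone, so the size of this step is not known. Compound 2 also carries hydroxy, though it differs elsewhere too. A small drop, near the edge of the scatter, is expected. For compound 4 the expected step is a number 9 percentage points lower from compound 3 to compound 4 (within the scatter), giving an estimate of 78%, within 62% to 94%.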

Compound 4, a percentage reported as activity, at one concentration (the size of the read-out at that concentration, not a potency): 84%
Estimate against measurement, compound 4: 6 percentage points below, and the stated range covers the measured number.
By their numbers in this assay, from the lowest: compounds 2, 1, 4 and 3 (each within the scatter of the next, the first and the last beyond it).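

In this assay, hydrogen in place of methyl on the oxygen, turning methoxy into hydroxy, gives a number 3 percentage points lower from compound 3 to compound 4 (within the scatter) at this first direct test of the change, so the two groups cannot be told apart here. With hydroxy held constant, dimethylamino in place of phenoxy gives a number 12 percentage points higher from compound 2 to compound 4 (beyond the scatter) in this one pair, so the stronger effect of compound 2 goes with phenoxy rather than hydroxy. No evidence on the cause of either step is available.

On these data alone, whether a longer chain on that oxygen, such as ethoxy, or an amine in place of the hydroxy would behave the same remains open. Only one concentration is shown, so these results speak only of a stronger or weaker effect at that concentration.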